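Sulfonyl replaced by trifluoromethyl carbonyl on the shared core

The compounds below may be only part of what the source reports. "The series", "measured", "known", "first", "only" and "open" are said of these compounds alone.

Compound 3 `O=S(=O)(Nc1cccc2c1CCCC2c1c[nH]cn1)C1CC1` gives 537 nM in an assay on isolated protein for binding affinity to Alpha-1A adrenergic receptor (Rattus norvegicus), read by radioligand binding; on this read-out lower numbers stand for stronger inhibition and higher numbers for weaker inhibition. Among the three measured compounds it holds the second highest number: compound 1 `CN(c1cccc2c1CCCC2c1c[nH]cn1)S(C)(=O)=O` gives 204 nM, and compound 2 `CCCS(=O)(=O)Nc1cccc2c1CCCC2c1c[nH]cn1` gives 1700 nM. The step of a 3.2-fold lower number from compound 2 to compound 3 (0.50 log units; beyond the scatter) and the step of a 2.6-fold higher number from compound 1 to compound 3 (0.42 log units; beyond the scatter) place compound 3 between the other two, while the step of an 8.3-fold higher number from compound 1 to compound 2 (0.92 log units; beyond the scatter) spans the whole measured range.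

Compound 4 `O=C(Nc1cccc2c1CCCC2c1c[nH]cn1)C(F)(F)F` differs from compound 3 by (trifluoromethyl)carbonyl in place of cyclopropylsulfonyl on a nitrogen on an aromatic ring. For the measured compounds named here, none of the measured steps bears directly on this change: all three compounds keep a sulfonyl group and differ only in what is attached to it or to the nitrogen, and their sizes run from the step of a 2.6-fold higher number from compound 1 to compound 3 (0.42 log units; beyond the scatter) up to the step of an 8.3-fold higher number from compound 1 to compound 2 (0.92 log units; beyond the scatter). Exchanging the sulfonyl for a carbonyl lies outside what those steps cover, so no direction can be read from them; a step of the size seen among the sulfonamides is taken as plausible, in either direction. Compound 4 is therefore expected near 800 nM, with a range from 200 nM to 3500 nM. The estimated step is a 1.5-fold higher number from compound 3 to compound 4 (0.17 log units; within the scatter).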

Compound 4, inhibition constant: 166 nM
Beside the measured number, compound 4's estimate is 4.8-fold (0.68 log units) above it; measured number outside the range, below it.
By their numbers in this assay, from the lowest: compounds 4 and 1 (each within the scatter of the next); then compound 3; then compound 2.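

Notes on the series: at this nitrogen on an aromatic ring, a sulfonyl group is not needed for the lower numbers in this assay, since (trifluoromethyl)carbonyl in place of cyclopropylsulfonyl gives a 3.2-fold lower number from compound 3 to compound 4 (0.51 log units; beyond the scatter), and in place of propylsulfonyl gives a 10-fold lower number from compound 2 to compound 4 (1.01 log units; beyond the scatter). Without a methyl on that nitrogen, the (trifluoromethyl)carbonyl group reaches the level of the methylated sulfonamide, with a 1.2-fold lower number from compound 1 to compound 4 (0.09 log units; within the scatter), so the two cannot be ordered. Nothing available on the compounds accounts for the effect of this exchange.

Going by these compounds, it remains open whether the lower number follows the carbonyl or the trifluoromethyl, a question that an acetyl group or a trifluoromethylsulfonyl group on the same nitrogen would address. Also open, on these data alone, is how a methyl on the nitrogen of compound 4 would shift the number.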